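From Phenyl to Pyridin-3-yl: One Change, One Expectation

A few compounds are considered here, and "the series" means these few. Any claim that something is new, unique, unknown or untested is made for them only; others in the source may bear on it.

Measured compounds:
Compound 1, `O=C1NC(=O)/C(=C/c2ccc(OCc3csc(-c4ccccc4)n3)cc2)S1`, gives 29.7% in a functional assay on the whole organism (plasma, strain Wistar) with Rattus norvegicus as the target, with a stated time of 15 days, at a dose of 100 mg/kg by the oral route; a higher number here means a stronger effect of the compound at the dose given, a lower number a weaker effect.
Compound 2, `O=C1NC(=O)/C(=C/c2ccc(OCCSc3nnc(-c4ccccc4)o3)cc2)S1`, gives 20.1% in this assay.

Going by the values given here, compound 2 holds the lower of the two numbers known so far, but its nearest neighbour, compound 1, lies within the scatter of repeated measurements, so the two cannot be told apart on this evidence. Compound 3, `O=C1NC(=O)/C(=C/c2ccc(OCCSc3nnc(-c4cccnc4)o3)cc2)S1`, has not yet been measured. It differs from compound 2 in a single place: pyridin-3-yl in place of phenyl on an aromatic carbon. Among the compounds with values here, no pair of measured compounds shows how such a change moves the read-out, since compound 1 and compound 2 differ in more than one place. With nothing to lean on, the expectation for this assay is a step that stays within the scatter, in no set direction. Compound 3 is therefore estimated to give about 20%, with a range from 8% to 35%. The estimated step, a number 0.1 percentage points lower from compound 2 to compound 3 (within the scatter), is expected to be small.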

Compound 3, a percentage reported as activity, at one dose (the size of the read-out at that dose, not a potency): 50.1%
Beside the measured number, compound 3's estimate is 30.1 percentage points below it; measured number above the stated range.
By their numbers in this assay, from the lowest: compounds 2 and 1 (each within the scatter of the next); then compound 3.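

Going by these compounds alone, replacing phenyl with pyridin-3-yl, on the aromatic carbon of the five-membered ring with 2 nitrogen and 1 oxygen, gives the first step in this assay that can be read from a single change: a number 30 percentage points higher from compound 2 to compound 3 (beyond the scatter). This shows that the read-out at this place depends on the group it carries, even when the two groups have the same count of heavy atoms and differ only in one ring nitrogen, which adds a hydrogen-bond acceptor to the count. Compound 1 and compound 2 could not show this, as they differ in more than one place, and nothing at hand says why the read-out moves.

The compounds shown leave open whether the ring nitrogen must sit where it does in pyridin-3-yl, since one step cannot say how pyridin-2-yl, pyridin-4-yl or a phenyl carrying an amine would behave at this place. As far as these compounds go, it also remains open whether pyridin-3-yl in place of the phenyl of compound 1 would move the read-out in the same way, so this single step cannot yet be called a pattern.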